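Trifluoromethyl to fluoro: the next step in the series

The source may hold more compounds than are shown below. What is called first, only, known or untested is meant among the compounds shown, and "the series" means these compounds.

Of the compounds shown here, three sharing one core have been measured so far in a functional assay on NCI-H661 cells (Homo sapiens) for antiproliferative activity, read by MTT assay, with a stated time of 72 h (on this read-out higher numbers stand for weaker inhibition and lower numbers for stronger inhibition), as the read-out. Compound 1 `O=C(CCCCCCc1nc(-c2ccccc2)no1)C(F)(F)F` gives the lowest number (520 nM). Compound 2 `COc1ccc(-c2noc(CCCCCCC(=O)C(F)(F)F)n2)cc1` gives 5050 nM and compound 3 `O=C(CCCCCCc1nc(-c2ccc(C(F)(F)F)cc2)no1)C(F)(F)F` gives 6390 nM on the same read-out. Compound 3 therefore shares the high end of the range with compound 2, and the gap between them stays within the scatter (a 1.3-fold higher number from compound 2 to compound 3 (0.10 log units; within the scatter)).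

The next structure is compound 4 `O=C(CCCCCCc1nc(-c2ccc(F)cc2)no1)C(F)(F)F`, with fluoro in place of trifluoromethyl on an aromatic carbon, para to a large group (fluoro in place of trifluoromethyl on an aromatic carbon).

Among the measured compounds shown here, two measured steps bear on this place. Both replace hydrogen and both lead to a higher number beyond the scatter: methoxy (a 9.7-fold higher number from compound 1 to compound 2 (0.99 log units; beyond the scatter)) and trifluoromethyl (a 12-fold higher number from compound 1 to compound 3 (1.09 log units; beyond the scatter)). For the measured compounds named here, no fluoro compound has been measured, so the data do not show how much of the step from hydrogen would remain. Compound 4 is expected to fall between compound 1 (520 nM) and compound 3 (6390 nM) in this assay as measured. The estimated step is a 3.6-fold lower number from compound 3 to compound 4 (0.55 log units; beyond the scatter) towards a lower number, modest in size and uncertain. For compound 4 the estimated value is 1800 nM (expected range 550 nM to 6000 nM).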

Compound 4, half-maximal inhibitory concentration: 12700 nM
The estimate for compound 4 lay 7.1-fold (0.85 log units) below the measured number; the measured number lies above the stated range.
By their numbers in this assay, from the lowest: compound 1; then compounds 2, 3 and 4 (each within the scatter of the next, the first and the last beyond it).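

In this assay, fluoro on this aromatic carbon, para to a large group, behaves like the other two replacements of hydrogen and gives no recovery towards compound 1, with a 24-fold higher number from compound 1 to compound 4 (1.39 log units; beyond the scatter), so even a group of 1 heavy atom does not retain the number seen with hydrogen. Fluoro and trifluoromethyl are not separated at this place (a 2.0-fold higher number from compound 3 to compound 4 (0.30 log units; within the scatter)), although fluoro does stand apart from methoxy (a 2.5-fold higher number from compound 2 to compound 4 (0.40 log units; beyond the scatter)), which leaves the three substituted compounds as a loose cluster rather than a clean order, since compound 3 lies within the scatter of both compound 2 and compound 4. No measurement is available that accounts for this result.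

The compounds shown leave open whether any group on this carbon, such as an amine or a hydroxyl, can keep the number near that of compound 1 at 520 nM. Also open, as far as these compounds go, is whether the same loss follows on another carbon of the aromatic ring, and whether a longer chain changes the size of the step from hydrogen.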